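A Tolerated Series Meets an Imidazole Amide

The source may hold more compounds than are shown below. What is called first, only, known or untested is meant among the compounds shown, and "the series" means these compounds.

Of the compounds shown here, three sharing one core have been tested in a toxicity assay on THP-1 cells (Homo sapiens) for inhibition (a lower number here means that less compound is tolerated, a higher number that more compound is tolerated), and none has yet given a plain number. Compound 1 `Cc1ccccc1-c1cnc(NC(=O)c2ccc(F)cc2)n1C` reads > 50000 nM, which is a limit of the assay. Compound 2 `COc1ccc(-c2cnc(NC(=O)c3ccc(F)cc3)n2C)cc1` reads >= 50000 nM, also a limit. Compound 3 `Cn1c(-c2cccc(C#N)c2)cnc1NC(=O)c1ccc(F)cc1` reads > 100000 nM, again a limit, so its true position is not known and it cannot be ranked against the other two.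

Compound 4 `Cn1c(-c2cccc(C#N)c2)cnc1NC(=O)c1ncc[nH]1` keeps the 3-cyanophenyl group of compound 3 but carries 1H-imidazol-2-yl in place of 4-fluorophenyl on a carbonyl carbon. The measured steps offer only indirect help. They are a step that the two limits leave unreadable from compound 1 to compound 2, a step that the two limits leave unreadable from compound 1 to compound 3 and a step that the two limits leave unreadable from compound 2 to compound 3, and all three change the group on an aromatic carbon, not the one on the carbonyl carbon. None has a readable size, so the data give no measured effect for this swap and no direction for it. Among the compounds with values here, the only guide is that all three tested compounds ended in limits, and the same outcome is expected here. The expected change is a number no higher from compound 3 to compound 4 (the limit leaves the size open), with no step beyond the scatter anticipated. For compound 4 the estimate is 100000 nM, with an expected range of 40000 nM to 150000 nM.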

Compound 4, half-maximal cytotoxic concentration: > 50000 nM
Compound 4: a limit, no number; the forecaster's own chance of this, stated with the estimate: 85%; the middle value does not contradict the limit.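

In this assay compound 4 gives > 50000 nM, which is a limit and not a number. Compound 3 also has only a limit, so the step between compound 3 and compound 4 cannot be read. The compounds shown leave open the concentration at which any of the four harms the cells, and whether 1H-imidazol-2-yl in place of 4-fluorophenyl changes it.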